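Halogen Swap on the Aryl Ring of a Succinimide Amide

The source may hold more compounds than are shown below. What is called first, only, known or untested is meant among the compounds shown, and "the series" means these compounds.

Of the compounds shown here, three sharing one core have been measured in a functional assay on the whole organism (strain Swiss) with Mus musculus as the target, in the maximal electroshock model, with a stated time of 0.5 h, at a dose of 100 mg/kg by the intraperitoneal route; on this read-out higher numbers stand for a stronger effect at the one dose given and lower numbers for a weaker effect. Compound 1 `CC(C(=O)N1CCN(c2ccc(Cl)cc2)CC1)N1C(=O)CCC1=O` gives 25%. Compound 2 `CCC(C(=O)N1CCN(c2cccc(F)c2)CC1)N1C(=O)CCC1=O` gives 0%, and compound 3 `CC(C(=O)N1CCN(c2cccc(F)c2)CC1)N1C(=O)CCC1=O` gives 0%. Compound 3 thus stands level with compound 2 at the digits printed, the two together forming the lowest of the three numbers, while compound 1 sits above it by a number 25 percentage points lower from compound 1 to compound 3 (beyond the scatter). The step of no change at the digits printed from compound 2 to compound 3 (within the scatter) shows that removing the methyl from the chain leaves the read-out unchanged within the scatter.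

Compound 4 `CC(C(=O)N1CCN(c2cccc(Cl)c2)CC1)N1C(=O)CCC1=O` differs from compound 3 by chloro in place of fluoro on an aromatic carbon. Among the measured compounds shown here, no measured step isolates the exchange of fluoro for chloro at the same carbon. For the measured compounds named here, the only step touching the aryl halogen, a number 25 percentage points lower from compound 1 to compound 3 (beyond the scatter), mixes a change of halogen with a change of its place on the ring, so its size cannot be assigned to either part alone. On that basis a small rise in this assay for compound 4 is expected, though a result within the scatter of compound 3 cannot be excluded. The expected step is a number 10 percentage points higher from compound 3 to compound 4 (within the scatter). Compound 4 is therefore estimated at 10%, within a range from 0% to 30%.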

Compound 4, a percentage reported as activity, at one dose (the size of the read-out at that dose, not a potency): 75%
Beside the measured number, compound 4's estimate is 65 percentage points below it; measured number above the stated range.
By their numbers in this assay, from the lowest: compounds 2 and 3 (each within the scatter of the next); then compound 1; then compound 4.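

At the aromatic carbon meta to a large group, chloro in place of fluoro gives a number 75 percentage points higher from compound 3 to compound 4 (beyond the scatter) in this assay, so the identity of the halogen at this one place is now seen on its own, a reading that the earlier step, which changed both the halogen and its place on the ring, could not give. With chloro held fixed and only its place on the ring changed, the outcome is a number 50 percentage points higher from compound 1 to compound 4 (beyond the scatter), which shows that the place of the halogen also matters in this series and that neither change is a small one here. The data at hand offer no measurement that would explain the size of either step.

The compounds shown leave open whether bromo or methoxy at the same carbon would give a read-out close to that of compound 4 or close to that of compound 3, and so whether chloro is special at this place. They also leave open whether a hydrogen in place of the chain methyl, which gave no change at the digits printed from compound 2 to compound 3 (within the scatter) among the 3-fluorophenyl compounds, would remain without effect on the 3-chlorophenyl compound.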